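This account rests on a few compounds, and the source may have more. Where it says the series, first, only, none or still open, it means among the compounds named here.

Compound 1 `COc1ccc(-c2ccc3ncnc(NCCN(C)C)c3c2)cn1` is the weaker of the two measured compounds in a functional assay on HCT-116 cells (Homo sapiens) for antiproliferative activity, read by MTT assay, with a stated time of 72 h; a lower number here means a stronger inhibitor, a higher number a weaker inhibitor: compound 1 gives 15900 nM, the higher of the two numbers on record. For the measured compounds named here, its only measured neighbour is compound 2 `COc1ncc(-c2ccc3ncnc(NCCN(C)C)c3c2)cc1C#N`, which in this assay gives 560 nM; that step, a 28-fold lower number from compound 1 to compound 2 (1.45 log units; beyond the scatter), comes from a cyano in place of hydrogen on an aromatic carbon.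

Compound 3 `CCN(CC)CCNc1ncnc2ccc(-c3ccc(OC)nc3)cc12` is related to compound 1 by a different change: diethylamino in place of dimethylamino on a saturated chain carbon, two bonds along the chain from a nitrogen on an aromatic ring. Going by the values given here, the one measured step concerns an aromatic carbon and a cyano group, not the saturated chain, so it does not speak to this change; nothing among the measured compounds reports what diethylamino in place of dimethylamino does. With no guidance either way, the expectation for this assay is a step that stays within the scatter, a 1.1-fold lower number from compound 1 to compound 3 (0.03 log units; within the scatter), and compound 3 is therefore expected to give about 15000 nM, with a range from 6000 nM to 40000 nM.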

Compound 3, half-maximal inhibitory concentration: 9560 nM
The estimate for compound 3 lay 1.6-fold (0.20 log units) above the measured number, and the stated range covers the measured number.
By their numbers in this assay, from the lowest: compound 2; then compounds 3 and 1 (each within the scatter of the next).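

With diethylamino in place of dimethylamino on a saturated chain carbon, two bonds along the chain from a nitrogen on an aromatic ring, the result in this assay is a 1.7-fold lower number from compound 1 to compound 3 (0.22 log units; within the scatter) and so compounds 1 and 3 cannot be told apart in this assay. For the compounds shown here, this is the first reading at this position, and it shows that two further carbon atoms at the chain end, with the nitrogen kept, leave the number inside the scatter, whereas the one step recorded on an aromatic carbon, a 28-fold lower number from compound 1 to compound 2 (1.45 log units; beyond the scatter) lies beyond it. No measurement of any other kind bears on this result, so nothing can be said about what lies behind it.

A single pair cannot show whether the same holds for other amines at this chain end, such as pyrrolidine, piperidine or morpholine, or for a longer chain between the two nitrogens. It also remains open whether diethylamino would behave in the same way when combined with the cyano group of compound 2, since no compound shown carries both groups.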